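The source may hold more compounds than are shown below. What is called first, only, known or untested is meant among the compounds shown, and "the series" means these compounds.

Compound 1 `COC(=O)c1scc(-c2ccc(NC(=O)c3ccc4ccccc4c3)cc2)c1OC` gives 18200 nM in a functional assay on HeLa cells (Homo sapiens) for antiproliferative activity, read by MTT assay, with a stated time of 24 h; a higher number here means a weaker inhibitor, a lower number a stronger inhibitor.
Compound 2 `COC(=O)c1scc(-c2ccc(NC(=O)c3ccc(C(F)(F)F)cc3Br)cc2)c1OC` gives 16200 nM in this assay.

Of these two numbers, compound 1 has the higher one, yet compound 2 lies within the scatter of it, so the pair shows no difference beyond the scatter. Compound 3 `COC(=O)c1scc(-c2ccc(NC(=O)c3cccc(I)c3)cc2)c1OC` has not yet been measured. It differs from compound 1 by 3-iodophenyl in place of naphthalen-2-yl on a carbonyl carbon. Among the compounds with values here, no step between measured compounds is known to guide this change, so the expected step is small, in either direction, and is estimated as a 1.1-fold higher number from compound 1 to compound 3 (0.04 log units; within the scatter). Compound 3 is therefore expected near 20000 nM, in the range 8000 nM to 50000 nM.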

Compound 3, half-maximal inhibitory concentration: 12700 nM
Compound 3: middle estimate off by 1.6-fold (0.20 log units), on the high side; low and high end bracket the measured number.
By their numbers in this assay, from the lowest: compounds 3, 2 and 1 (each within the scatter of the next).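

In this assay, within the data shown here, the step of 3-iodophenyl in place of naphthalen-2-yl on a carbonyl carbon is a 1.4-fold lower number from compound 1 to compound 3 (0.16 log units; within the scatter) and gives the first reading of a single change at this position. Going from two aromatic rings to one that carries iodine thus leaves the number within the scatter, so this change shows no measurable effect here. Nothing at hand bears on the reason for this result. Still open, going by these compounds, is whether an amine or a carboxylic acid on the carbonyl carbon would move the number beyond the scatter. Also open, on these data alone, is whether any group at this position can do so.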